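This account rests on a few compounds, and the source may have more. Where it says the series, first, only, none or still open, it means among the compounds named here.

Measured so far:
- compound 1 `Cc1nnc(CN2CCCC2)n1-c1ccc(Cl)cc1C(=O)c1ccccc1`: 0.4 mg/kg
- compound 2 `Cc1nnc(CN2CCCC2)n1-c1ccc(Cl)cc1C(=O)c1ccccc1Cl`: 1.8 mg/kg

In a functional assay on the whole organism (strain CF-1) for inhibition, with Mus musculus as the target (a lower number here means that less compound is needed, a higher number that more compound is needed for the effect), compound 1 stands with the lowest of the two numbers; its nearest neighbour is compound 2, and the step of a 4.5-fold higher number from compound 1 to compound 2 (0.65 log units; beyond the scatter) is the only one measured. That step concerns a chloro in place of hydrogen on an aromatic carbon and says nothing about the part of the molecule changed next.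

Compound 3 `CCNCc1nnc(C)n1-c1ccc(Cl)cc1C(=O)c1ccccc1` differs from compound 1 by ethylamino in place of pyrrolidin-1-yl on a saturated chain carbon bound to an aromatic carbon. Going by the values given here, no measured pair touches this position, so there is no step to lean on; the only guide is that the shared core and the rest of compound 1 stay untouched. Compound 3 is therefore expected to land near compound 1, with a step of a 2.0-fold higher number from compound 1 to compound 3 (0.30 log units; within the scatter) in this assay that need not exceed the scatter. The estimate for compound 3 is 0.8 mg/kg, with a range from 0.2 mg/kg to 3 mg/kg.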

Compound 3, dose for half-maximal effect: 0.2 mg/kg
Compound 3: middle estimate off by 4.0-fold (0.60 log units), on the high side, within the range that was stated.
By their numbers in this assay, from the lowest: compounds 3 and 1 (each within the scatter of the next); then compound 2.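

In this assay the change to ethylamino in place of pyrrolidin-1-yl on a saturated chain carbon bound to an aromatic carbon gives (a 2.0-fold lower number from compound 1 to compound 3 (0.30 log units; within the scatter)), the first step measured at this position. The two compounds therefore read alike even though the five-membered ring is gone and a hydrogen-bond donor has entered, so a ring is not needed here for a number this low. Nothing at hand explains why these two groups read alike.

As far as these compounds go, it remains open whether methylamino or a longer chain such as butylamino would stay in the same range, and whether dimethylamino, with no hydrogen on its nitrogen, would match them. From the compounds shown here alone, it is also open whether chloro in place of hydrogen on an aromatic carbon would give a similar step with ethylamino present.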